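Swapping an ester for an anilide: expected cell toxicity

This account rests on a few compounds, and the source may have more. Where it says the series, first, only, none or still open, it means among the compounds named here.

Of the compounds shown here, three from one series have been tested in a toxicity assay on L02 cells (Homo sapiens) for cytotoxicity, read by MTT assay, with a stated time of 24 h; on this read-out higher numbers stand for lower toxicity in this test and lower numbers for higher toxicity in this test. Compound 1 `CCCCS(=O)(=O)Oc1ccc(/C=C/C(=O)Nc2ccccc2C)cc1OC` gives 56100 nM in this assay. Compound 2 `COc1cc(/C=C/C(=O)Nc2cccc(C)c2)ccc1OS(=O)(=O)c1ccc(Cl)cc1` gives 73500 nM in this assay. Compound 3 `CCCCS(=O)(=O)Oc1ccc(/C=C/C(=O)OCCC)cc1OC` gives 61800 nM in this assay, which places it second highest of the three numbers, though its gaps to compound 1 and to compound 2 both lie within the usual scatter.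

The unmeasured compound 4 `CCCCS(=O)(=O)Oc1ccc(/C=C/C(=O)Nc2cccc(C)c2)cc1OC` differs from compound 3 in one place: (3-methylphenyl)amino in place of propoxy on a carbonyl carbon. Within the data shown here, the only measured step that bears on this change is the one in the other direction, from the (2-methylphenyl)amino of compound 1 to the propoxy of compound 3, which gave a 1.1-fold higher number from compound 1 to compound 3 (0.04 log units; within the scatter). Compound 2 carries the same (3-methylphenyl)amino group as compound 4 and sits within the scatter of compound 3, so nothing in these numbers points to a step beyond the scatter in either direction.

Compound 4 is therefore expected to give about 60000 nM in this assay, with a range from 30000 nM to 120000 nM. This estimate means a step of a 1.0-fold lower number from compound 3 to compound 4 (0.01 log units; within the scatter), which is expected to stay within the scatter.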

Compound 4, half-maximal cytotoxic concentration: 33600 nM
Compound 4: the middle estimate sits 1.8-fold (0.25 log units) above what was measured; the range from low to high includes it.
By their numbers in this assay, from the lowest: compounds 4, 1, 3 and 2 (each within the scatter of the next, the first and the last beyond it).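

In this assay, the carbonyl carbon accepts a much larger group without a clear shift: (3-methylphenyl)amino in place of propoxy, which brings in an aromatic ring and the amide hydrogen, gives a 1.8-fold lower number from compound 3 to compound 4 (0.26 log units; within the scatter) and so stays close to the ester. Moving the methyl on the aromatic ring also leaves the result within the scatter, since 3-methylphenyl in place of 2-methylphenyl on the amide-type nitrogen gives a 1.7-fold lower number from compound 1 to compound 4 (0.22 log units; within the scatter). Among these compounds, the only step here beyond the scatter lies at the other end of the molecule, where butyl in place of 4-chlorophenyl on the sulfonyl sulfur gives a 2.2-fold lower number from compound 2 to compound 4 (0.34 log units; beyond the scatter), a modest rise in toxicity in this test for which no measurement here offers an explanation.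

From the compounds shown here alone, that sulfonyl step rests on a single pair, so it remains open whether butyl and 4-chlorophenyl would differ in the same way with propoxy or (2-methylphenyl)amino on the carbonyl carbon. Also open is whether a carboxylic acid, an amine-bearing chain or a longer alkoxy chain on that carbon would stay as close to these compounds as the groups shown.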